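Series notes: chain extension step from compound 1

This account rests on a few compounds, and the source may have more. Where it says the series, first, only, none or still open, it means among the compounds named here.

Compound 1 `C/N=C(/NC#N)NCCCn1nc(-c2ccccc2)ccc1=O` gives 40.5% in a functional assay on the whole organism with Rattus norvegicus as the target, at a dose of 100 mg/kg (on this read-out lower numbers stand for less inhibition and higher numbers for more inhibition at the one dose given (going by the name of the read-out)), and stands second highest of the three numbers. Compound 3 `C/N=C(/NC#N)NCCCn1nc(-c2ccccc2)cc(C)c1=O` gives 42.8%, and a number 2.3 percentage points higher from compound 1 to compound 3 (within the scatter). Compound 2 `C/N=C(/NC#N)NCCCn1nc(-c2ccccc2)c(C)cc1=O` gives 17.2%, and a number 23.3 percentage points lower from compound 1 to compound 2 (beyond the scatter). Compound 4 `C/N=C(\NC#N)NCCCCn1nc(-c2ccccc2)ccc1=O` is not yet measured; it differs from compound 1 by a group of 8 heavy atoms (4 carbon, 4 nitrogen; no ring) in place of a group of 7 heavy atoms (3 carbon, 4 nitrogen; no ring), on a saturated chain carbon, three bonds along the chain from an aromatic nitrogen. Neither measured step bears on this change: both put a methyl on an aromatic carbon and leave the chain untouched, so the chain change has no precedent among these compounds. With no guide, no shift beyond the scatter is expected, and the estimated step is a number 4.5 percentage points lower from compound 1 to compound 4 (within the scatter), carrying a wide range for the uncertainty. Compound 4 is therefore estimated at 36%, between 15% and 58%.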

Compound 4, a percentage reported as inhibition, in the whole organism at one dose (the size of the read-out at that dose, not a potency): 79%
Estimate against measurement, compound 4: 43 percentage points below; the whole stated range lies below it.
By their numbers in this assay, from the lowest: compound 2; then compounds 1 and 3 (each within the scatter of the next); then compound 4.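

In this assay, the saturated chain is a place where the read-out responds: a group of 8 heavy atoms in place of a group of 7 heavy atoms gives a number 38.5 percentage points higher from compound 1 to compound 4 (beyond the scatter). Among the compounds shown here, compound 2 and compound 3 left this chain untouched, so this is the first sign that a change there can shift the number upward. Nothing measured here accounts for the step.

From the compounds shown here alone, whether a still longer chain would carry the rise further remains open. Also open, going by these compounds, are the effect of an amine on the chain and whether methyl on the aromatic carbon acts the same way with the longer chain.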